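This account rests on a few compounds, and the source may have more. Where it says the series, first, only, none or still open, it means among the compounds named here.

- Compound 1 `NC(=O)c1cc(Cl)ccc1NC(=O)COc1ccccc1`: 4330 nM
- Compound 2 `NC(=O)c1cc(I)ccc1NC(=O)COc1ccccc1`: 553 nM
- Compound 3 `COc1ccc(NC(=O)COc2ccccc2)c(C(N)=O)c1`: not yet measured

For the measured compounds named here, in a functional assay on RPMI-8226 cells (Homo sapiens) for inhibition (a higher number here means a weaker inhibitor of growth, a lower number a stronger inhibitor of growth), compound 2 gives 553 nM, the lower of the two numbers so far, which makes it the stronger growth inhibitor of the pair. Going by the values given here, the only measured step, a 7.8-fold lower number from compound 1 to compound 2 (0.89 log units; beyond the scatter), is iodo in place of chloro on an aromatic carbon, and it lies beyond the scatter.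

The next change is methoxy in place of iodo on an aromatic carbon, meta to a carbamoyl group and para to a large group. Among the compounds with values here, no measured compound carries methoxy, so the evidence is indirect. It does show that the group at this place matters, since compound 1, with chloro rather than iodo, sits at 4330 nM. Within the data shown here, with only one step to go on, the reasonable expectation is that removing iodo gives up much of that gain, so the number should rise by a step of similar size, beyond the scatter. The expected change is a 5.4-fold higher number from compound 2 to compound 3 (0.73 log units; beyond the scatter). For compound 3 the estimated value in this assay is 3000 nM, with an expected range of 800 nM to 11000 nM.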

Compound 3, concentration for 50% growth inhibition: 1170 nM
For compound 3 the middle estimate is 2.6-fold (0.41 log units) above the measured one, and the stated range covers the measured number.
By their numbers in this assay, from the lowest: compound 2; then compound 3; then compound 1.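

In this assay, methoxy in place of iodo gives a 2.1-fold higher number from compound 2 to compound 3 (0.33 log units; beyond the scatter) and so loses part of the strength seen with iodo, yet methoxy in place of chloro gives a 3.7-fold lower number from compound 1 to compound 3 (0.57 log units; beyond the scatter) and so improves on chloro. The methoxy compound therefore falls between the two halogen compounds, which shows that a halogen is not needed at this position for a lower number and that the two halogens tested do not behave as one group here. Iodo remains the best of the three groups compared on this otherwise unchanged core, but nothing in the available data explains this order.

Three groups at one position are too few to establish a trend, and the results do not show whether another kind of group could match or beat iodo in compound 2. An amine, a carboxylic acid, bromo or a longer chain such as ethoxy at the same place would test whether the order seen here extends beyond these three compounds.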